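Cytotoxicity notes: from compound 1 to compound 3

This account rests on a few compounds, and the source may have more. Where it says the series, first, only, none or still open, it means among the compounds named here.

compound 1 `COc1ccc(S(=O)(=O)Nc2ccc(-c3nc4cc(NS(=O)(=O)c5ccc(OC)cc5)ccc4o3)cc2)cc1` gives 48000 nM
compound 2 `Nc1ccc(S(=O)(=O)Nc2ccc(-c3nc4cc(NS(=O)(=O)c5ccc(N)cc5)ccc4o3)cc2)cc1` gives 63000 nM

Both values come from an ADME assay on HEK293 cells (Homo sapiens) for cytotoxicity, read by resazurin assay, with a stated time of 48 h (a lower number here means that less compound is tolerated, a higher number that more compound is tolerated), and lie within the usual scatter of each other, so compound 1 stands level with compound 2 and the pair gives no order. For the measured compounds named here, no pair of measured compounds differs in a single place, so the series offers no direct guide to the size of any one structural change.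

Going by the values given here, compound 3 `COc1ccc(S(=O)(=O)Nc2ccc3oc(-c4ccc(NC(=O)C5CCN(C(C)=O)CC5)cc4)nc3c2)cc1` remains unmeasured in this assay so far. The change (1-acetylpiperidin-4-yl)carbonyl in place of (4-methoxyphenyl)sulfonyl on a nitrogen on an aromatic ring puts (1-acetylpiperidin-4-yl)carbonyl in place of (4-methoxyphenyl)sulfonyl on a nitrogen on an aromatic ring. Among the compounds with values here, with no measured step to draw on, no shift beyond the scatter is expected in this assay and no direction is favoured. Within the data shown here, that expectation rests only on compound 1 at 48000 nM and compound 2 at 63000 nM as the sole reference values. The estimated move a 1.1-fold higher number from compound 1 to compound 3 (0.06 log units; within the scatter) is expected to stay small. Compound 3 is estimated at 55000 nM within an expected range from 22000 nM to 100000 nM for this read-out.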

Compound 3, half-maximal cytotoxic concentration: 34000 nM
Compound 3: the middle estimate sits 1.6-fold (0.21 log units) above what was measured; low and high end bracket the measured number.
By their numbers in this assay, from the lowest: compounds 3, 1 and 2 (each within the scatter of the next).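

In this assay, for the compounds shown here, the step of a 1.4-fold lower number from compound 1 to compound 3 (0.15 log units; within the scatter) is the only single-place comparison so far, and it lies within the scatter. At this position, on a nitrogen on an aromatic ring, ((4-methoxyphenyl)sulfonyl)amino and ((1-acetylpiperidin-4-yl)carbonyl)amino therefore stand level, even though the exchange swaps a six-membered aromatic ring of carbon only for a six-membered non-aromatic ring with 1 hetero atom and removes the sulfur. Nothing available bears on why the two groups read alike.

On these data alone, whether an amine or a carboxylic acid in place of the acetyl group of (1-acetylpiperidin-4-yl)carbonyl, or a longer chain on that carbonyl, would move the number beyond the scatter remains open. Also open, as far as these compounds go, is whether the same exchange, made on the (4-methoxyphenyl)sulfonyl group that compound 3 keeps, would likewise stay within the scatter.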